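Ethoxy Replacing Amino on a Shared Thiazole-Free Core Description

A few compounds are considered here, and "the series" means these few. Any claim that something is new, unique, unknown or untested is made for them only; others in the source may bear on it.

Of the compounds shown here, two built on one shared core have been measured. Compound 1, `Oc1ccc(Nc2nc(-c3ccc(F)cc3)cs2)cc1`, gives 700 nM in an assay on isolated protein for inhibition of Polyunsaturated fatty acid 5-lipoxygenase (Homo sapiens), with stated times of 15 min and 10 min; a higher number here means a weaker inhibitor, a lower number a stronger inhibitor. Going by the values given here, compound 2, `Nc1ccc(-c2csc(Nc3ccc(O)cc3)n2)cc1`, gives 4400 nM in this assay, the higher of the two numbers measured so far; its nearest neighbour is compound 1, and the step of a 6.3-fold higher number from compound 1 to compound 2 (0.80 log units; beyond the scatter) is the only one recorded. The next compound, compound 3, `CCOc1ccc(-c2csc(Nc3ccc(O)cc3)n2)cc1`, is not yet measured. It differs from compound 2 in one place: ethoxy in place of amino on an aromatic carbon, on an aromatic carbon of a six-membered aromatic ring of carbon only, para to a large group. Among the compounds with values here, only the step from compound 1 to compound 2 bears on this change, and it concerns fluoro against amino, not ethoxy; it shows that exchanging the group at this position can move the number well beyond the scatter. Ethoxy is neither of the two groups already tried, so the direction is uncertain, but with amino leaving, compound 3 is expected to return part of the way toward compound 1, an expected step of a 2.9-fold lower number from compound 2 to compound 3 (0.47 log units; beyond the scatter). The estimate for compound 3 in this assay is 1500 nM, within a range of 400 nM to 6000 nM.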

Compound 3, half-maximal inhibitory concentration: 600 nM
For compound 3 the middle estimate is 2.5-fold (0.40 log units) above the measured one; the range from low to high includes it.
By their numbers in this assay, from the lowest: compounds 3 and 1 (each within the scatter of the next); then compound 2.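

Ethoxy in place of amino on this aromatic carbon, para to a large group, gives a 7.3-fold lower number from compound 2 to compound 3 (0.87 log units; beyond the scatter) in this assay, so the earlier loss seen with amino, a 6.3-fold higher number from compound 1 to compound 2 (0.80 log units; beyond the scatter), is not a general result of exchanging fluoro at this position. With a 1.2-fold lower number from compound 1 to compound 3 (0.07 log units; within the scatter), fluoro and ethoxy cannot be told apart here, even though ethoxy brings more heavy atoms than the amino it replaces, so among the three groups on the shared core it is amino that stands apart, and a larger group at this position does not by itself raise the number. Nothing shown here measures what sets amino apart from the other two groups.

Three groups are too few to show how far this position reaches, so a shorter methoxy or a longer chain such as butoxy could either stay level with ethoxy or move away from it. As far as these compounds go, it also remains open whether a substituted nitrogen, such as dimethylamino or an acetyl amide, behaves like amino or more like ethoxy and fluoro.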